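The source may report more compounds than this note shows. Statements on the series, on what has been measured and on what is new or still open speak of the compounds shown alone.

Measured so far:
compound 1 `O=c1oc2ccccc2n1CC1CCN(Cc2ccc(Cl)cc2Cl)CC1` — 258 nM
compound 2 `Cc1ccc(CN2CCC(Cn3c(=O)oc4ccccc43)CC2)cc1` — 2.9 nM

In an assay on membranes from liver for displacement of a labelled ligand from Sigma non-opioid intracellular receptor 1 (Rattus norvegicus) (a lower number here means a stronger inhibitor, a higher number a weaker inhibitor), compound 2 holds the lowest of the two numbers; its nearest neighbour is compound 1, from which it differs by an 89-fold lower number from compound 1 to compound 2 (1.95 log units; beyond the scatter). Compound 3 `Cc1ccc(CN2CCC(Cn3c(=O)oc4ccccc43)CC2)c(C)c1` carries methyl in place of hydrogen on an aromatic carbon, on an aromatic carbon ortho to a large group and meta to a methyl group, so 4-methylphenyl becomes 2,4-dimethylphenyl. Among the measured compounds shown here, only the step from compound 1 to compound 2 touches this ring, and it changes both positions at once, so no measured step isolates a single added methyl. For compound 3 a step of a 1.4-fold higher number from compound 2 to compound 3 (0.14 log units; within the scatter) is expected in this assay, close to the scatter. Compound 3 is estimated at 4 nM, between 1.2 nM and 15 nM.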

Compound 3, inhibition constant: 30 nM
Estimate against measurement, compound 3: 7.5-fold (0.88 log units) below; measured number above the stated range.
By their numbers in this assay, from the lowest: compound 2; then compound 3; then compound 1.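

In this assay, methyl in place of hydrogen on the aromatic carbon ortho to a large group gives a 10-fold higher number from compound 2 to compound 3 (1.01 log units; beyond the scatter) and shows that one added methyl at this place is not neutral on 4-methylphenyl. With both rings carrying the same substitution pattern, 2,4-dimethylphenyl in place of 2,4-dichlorophenyl gives an 8.6-fold lower number from compound 1 to compound 3 (0.93 log units; beyond the scatter) and so keeps part of the earlier gain. Nothing available here bears on the reason for either step.

As far as these compounds go, whether the rise belongs to methyl alone or to any group on this carbon, such as fluorine or methoxy, remains open.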